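A cinnamate in place of a benzoate on an inactive core

The source may report more compounds than this note shows. Statements on the series, on what has been measured and on what is new or still open speak of the compounds shown alone.

In a functional assay on KB cells (Homo sapiens) for inhibition, read by MTT assay, with a stated time of 72 h (on this read-out higher numbers stand for weaker inhibition and lower numbers for stronger inhibition), compound 1 `C/C1=C\[C@@H]2[C@H](C[C@@H](O)[C@@]3(C)O[C@@H]3[C@H]3[C@@H](OC(=O)c4ccccc4)[C@@H](C)C[C@]3(O)C1=O)C2(C)C` gives only a limit, > 30000 nM. Compound 2 `C[C@H]1C[C@]2(OC(=O)/C=C/c3ccccc3)C(=O)/C(CO)=C/[C@@H]3[C@H](CC[C@@]4(C)O[C@H]4[C@H]2[C@H]1O)C3(C)C` likewise gives only a limit, > 30000 nM. Compound 3 `C/C1=C\[C@@H]2[C@H](CC[C@@]3(C)O[C@@H]3[C@H]3[C@@H](O)[C@@H](C)C[C@]3(OC(=O)c3ccccc3)C1=O)C2(C)C` also gives only a limit, > 30000 nM. Going by the values given here, compound 3 thus stands where both other compounds stand, at the limit of > 30000 nM in this assay, at which 3 of the 3 values shown sit, and no step between measured compounds can be sized. Compound 4 `C/C1=C\[C@@H]2[C@H](CC[C@@]3(C)O[C@@H]3[C@H]3[C@@H](O)[C@@H](C)C[C@]3(OC(=O)/C=C/c3ccccc3)C1=O)C2(C)C` differs from compound 3 by 2-phenylethenyl in place of phenyl on a carbonyl carbon. Compound 2 already carries 2-phenylethenyl on its carbonyl carbon and reaches only a limit, so the step in this assay is expected to be a number no higher from compound 3 to compound 4 (the limit leaves the size open), none beyond the scatter. Compound 4 is therefore expected to give 30000 nM, between 10000 nM and 100000 nM, most probably again only a limit.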

Compound 4, half-maximal inhibitory concentration: 19800 nM
The estimate for compound 4 lay 1.5-fold (0.18 log units) above the measured number; measured number inside the range.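

In this assay, going by these compounds alone, compound 4 gives 19800 nM, the first number in this set that is not a limit. Putting 2-phenylethenyl in place of phenyl on this carbonyl carbon brings an at least 1.5-fold lower number from compound 3 to compound 4 (0.18 log units; that floor lies within the scatter). Going by these compounds, only that floor can be read, and the true size of the step stays open, as the parent compound sits at the assay's ceiling: the limit of > 30000 nM in this assay, at which 3 of the 4 values shown sit.

On these data alone, whether an amine, a carboxylic acid or a longer chain on this carbonyl carbon would move the number beyond the scatter stays open.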